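The source may report more compounds than this note shows. Statements on the series, on what has been measured and on what is new or still open speak of the compounds shown alone.

Values so far:
- Compound 1 `O=C1OCCc2c(CO)cccc21`: > 3800000 nM, a limit
- Compound 2 `NC(=O)c1cccc2c1CCOC2=O`: > 3290000 nM, a limit

In an ADME assay on HepG2 2.2.15 cells (Homo sapiens) for cytotoxicity, read by MTT assay, with a stated time of 72 h (on this read-out lower numbers stand for higher toxicity in this test and higher numbers for lower toxicity in this test), compound 2 stands at > 3290000 nM, which is a limit and not a number. Compound 3 `N=C(N)c1cccc2c1CCOC2=O` differs from it on an aromatic carbon, where the carbamoyl leaves: a group of 3 heavy atoms (1 carbon, 2 nitrogen; no ring) in place of a group of 3 heavy atoms (1 carbon, 1 nitrogen, 1 oxygen; no ring), on an aromatic carbon. Going by the values given here, only one measured step bears on this, a step that the two limits leave unreadable from compound 1 to compound 2, and it gives no size to build on. No step beyond the usual scatter is therefore expected in this assay, and another limit is likely. The expected step is an at least 1.0-fold lower number from compound 2 to compound 3 (0.04 log units; that floor lies within the scatter). Compound 3 is estimated at 3000000 nM, with an expected range of 1000000 nM to 5000000 nM.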

Compound 3, half-maximal cytotoxic concentration: 2050000 nM
For compound 3 the middle estimate is 1.5-fold (0.17 log units) above the measured one, and the stated range covers the measured number.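

In this assay, going by these compounds alone, compound 3 gives the first actual number at this aromatic carbon, where the earlier compounds gave only limits. Putting the new group in place of carbamoyl gives an at least 1.6-fold lower number from compound 2 to compound 3 (0.20 log units; that floor lies within the scatter), and putting it in place of hydroxymethyl gives an at least 1.8-fold lower number from compound 1 to compound 3 (0.26 log units; that floor lies within the scatter). The first of these steps is bounded on one side only, as compound 2 has a limit and not a number: the limit of > 3290000 nM in this assay, at which 1 of the 3 values shown sits.

The compounds shown leave open whether an amine or a carboxylic acid on this aromatic carbon would give a number or a limit. They also leave open what a longer chain there would give.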